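Biaryl ring swap on the propanoic acid thiophene series

A few compounds are considered here, and "the series" means these few. Any claim that something is new, unique, unknown or untested is made for them only; others in the source may bear on it.

Within the data shown here, compound 2 `Cc1cccc(C)c1-c1cccc(COc2ccc(CCC(=O)O)s2)c1` stands at the low end of the three numbers so far: in a functional assay on cells for agonist activity at Free fatty acid receptor 1 (Homo sapiens), read by calcium flux (a lower number here means that less compound is needed, a higher number that more compound is needed for the effect), compound 2 gives 32 nM. Compound 3 `CCO[C@H](CC(=O)O)c1ccc(OCc2cccc(-c3c(C)cccc3C)c2)s1` gives 50 nM, and the step of a 1.6-fold higher number from compound 2 to compound 3 (0.19 log units; within the scatter) leaves the two within the scatter, so neither is set apart from the other. Compound 1 `CC#CC(CC(=O)O)c1ccc(OCc2cccc(-c3c(C)cccc3C)c2)s1` gives 210 nM; the steps of a 6.6-fold lower number from compound 1 to compound 2 (0.82 log units; beyond the scatter) and a 4.2-fold lower number from compound 1 to compound 3 (0.62 log units; beyond the scatter) are both beyond the scatter and both concern the substituent on the saturated chain carbon bound to the aromatic carbon.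

Compound 4 `COc1ccc(F)c(-c2cccc(COc3ccc(CCC(=O)O)s3)c2)c1` differs from compound 2 only in the biaryl ring: 2-fluoro-5-methoxyphenyl in place of 2,6-dimethylphenyl on an aromatic carbon. Among the measured compounds shown here, none of the measured steps touches the 2,6-dimethylphenyl group, so no direct guide exists for this change; the steps measured so far were all of modest size. Compound 4 is therefore expected to sit near compound 2, with a step of about a 1.9-fold higher number from compound 2 to compound 4 (0.27 log units; within the scatter) toward a higher number. The estimate for compound 4 is 60 nM, with a range from 15 nM to 250 nM.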

Compound 4, half-maximal effective concentration: 580 nM
For compound 4 the middle estimate is 9.7-fold (0.99 log units) below the measured one; the whole stated range lies below it.
By their numbers in this assay, from the lowest: compounds 2 and 3 (each within the scatter of the next); then compound 1; then compound 4.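

In this assay, the ring on the aromatic carbon, meta to a large group, proves a sensitive place in the series: an 18-fold higher number from compound 2 to compound 4 (1.26 log units; beyond the scatter) is a larger step than the largest one seen on the chain substituent, a 6.6-fold lower number from compound 1 to compound 2 (0.82 log units; beyond the scatter). This single step replaces both methyl groups of 2,6-dimethylphenyl and brings in fluoro and methoxy together, so it gives the effect of the whole exchange and cannot be divided among those groups. No supporting measurement explains the size of this step.

The compounds shown leave open how much of the step belongs to fluoro and how much to methoxy, which a phenyl bearing only one of these groups, or a plain phenyl, would help to separate. On these data alone, whether 2-fluoro-5-methoxyphenyl behaves the same way alongside the ethoxy chain of compound 3 also remains open.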